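A few compounds are considered here, and "the series" means these few. Any claim that something is new, unique, unknown or untested is made for them only; others in the source may bear on it.

Of the compounds shown here, two have been tested in an ADME assay on HepG2 2.2.15 cells (Homo sapiens) for cytotoxicity; a lower number here means that less compound is tolerated, a higher number that more compound is tolerated. Compound 1 `O=c1[nH]c2ccc(Cl)cc2c(-c2ccccc2)c1CCO` reaches a limit of this assay, > 4910000 nM, and so gives no number. Among the compounds with values here, compound 2 `Nc1c(-c2ccccc2Cl)c2cc(Cl)ccc2[nH]c1=O` gives 341000 nM, the only numerical value here. Compound 3 `O=c1[nH]c2ccc(Cl)cc2c(-c2ccccc2Cl)c1CCO` differs from compound 2 in one place: 2-hydroxyethyl in place of amino on an aromatic carbon. Within the data shown here, no measured pair shows this step, so its size is open, but a rise beyond the scatter is expected because compound 1, which also carries 2-hydroxyethyl, sits at the limit of > 4910000 nM in this assay, at which 1 of the 2 values shown sits. Compound 3 is expected to give 2000000 nM, between 400000 nM and 5000000 nM, a step of a 5.9-fold higher number from compound 2 to compound 3 (0.77 log units; beyond the scatter).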

Compound 3, half-maximal cytotoxic concentration: 1720000 nM
Beside the measured number, compound 3's estimate is 1.2-fold (0.07 log units) above it; the range from low to high includes it.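

Putting 2-hydroxyethyl in place of amino on this aromatic carbon now has a measured size in this assay, with a 5.0-fold higher number from compound 2 to compound 3 (0.70 log units; beyond the scatter). The second change, chloro in place of hydrogen on an aromatic carbon, also moves the number, with an at least 2.8-fold lower number from compound 1 to compound 3 (0.45 log units; beyond the scatter). This second step rests on compound 1, whose > 4910000 nM is a limit of the assay.

Going by these compounds, only amino and 2-hydroxyethyl appear at this position, so it remains open how a longer chain or a carboxylic acid there would compare. On these data alone, the effect of chloro in place of hydrogen with amino on the core also remains open.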